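Side chain change on the shared core: solubility notes

The source may report more compounds than this note shows. Statements on the series, on what has been measured and on what is new or still open speak of the compounds shown alone.

- Compound 1 `COc1nn(C)c2ncnc(NS(=O)(=O)c3cccc(Cl)c3Cl)c12` gives the limit >= 581000 nM as its reading
- Compound 2 `CNC(=O)Cn1nc(OC)c2c(NS(=O)(=O)c3cccc(Cl)c3Cl)ncnc21` gives the limit >= 509000 nM as its reading

In a physicochemical assay for solubility, read by chemiluminescence, measured as kinetic solubility (a higher number here means a more soluble compound, a lower number a less soluble compound), compound 2 stands only at the limit >= 509000 nM and has no numerical reading. Compound 3 `COCCn1nc(OC)c2c(NS(=O)(=O)c3cccc(Cl)c3Cl)ncnc21` carries methoxymethyl in place of methylcarbamoyl on a saturated chain carbon bound to an aromatic nitrogen. For the measured compounds named here, the only measured step bearing on this is a step that the two limits leave unreadable from compound 1 to compound 2 and it has no readable size, so no step beyond the scatter is expected in this assay for this change. The expected step is an at least 1.0-fold lower number from compound 2 to compound 3 (0.02 log units; that floor lies within the scatter) as estimated here. For compound 3 the estimated value is 480000 nM with an expected range from 220000 nM to 620000 nM as its upper end.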

Compound 3, solubility: >= 442000 nM
Compound 3: a limit, no number; the forecaster's own chance of this, stated with the estimate: 60%; the middle value lies beyond the limit too.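

In this assay, for the compounds shown here, compound 1, compound 2 and compound 3 all give limits rather than numbers, and no step among them can be read. From the compounds shown here alone, whether their side chains differ at all in solubility stays open.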